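Acetylated and free-hydroxyl thioglycoside amides, cytotoxicity notes

A few compounds are considered here, and "the series" means these few. Any claim that something is new, unique, unknown or untested is made for them only; others in the source may bear on it.

The series is built on a thioglycoside core carrying an amide chain, read in a functional assay on HeLa cells (Homo sapiens) for cytotoxicity, read by MTT assay, with a stated time of 24 h; a lower number here means a stronger inhibitor, a higher number a weaker inhibitor. Compound 1 `CCCCCCCC/C=C\CCCCCCCC(=O)Nc1nnc(S[C@@H]2O[C@H](COC(C)=O)[C@H](OC(C)=O)[C@H](OC(C)=O)[C@H]2OC(C)=O)s1` carries the acetylated sugar with the long unsaturated chain and gives 54400 nM. Compound 2 `CCCCCCCC/C=C\CCCCCCCC(=O)Nc1nnc(S[C@@H]2O[C@H](CO)[C@H](O)[C@H](O)[C@H]2O)s1` has the same chain on the free-hydroxyl sugar and gives 8800 nM. How the core of compound 1 differs from that of compound 2 is not broken down here; their two values are simply as stated. Compound 3 `CCCCCC(=O)Nc1nnc(S[C@@H]2O[C@H](CO)[C@H](O)[C@H](O)[C@H]2O)s1` keeps the free-hydroxyl core but with the short chain, and in this assay compound 3 gives 45600 nM.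

Among the measured compounds shown here, the one measured step is hydrogen in place of dodec-3-en-1-yl on a saturated chain carbon, five bonds along the chain from a carbonyl carbon, which produced a 5.2-fold higher number from compound 2 to compound 3 (0.71 log units; beyond the scatter).

Compound 4 `CCCCCC(=O)Nc1nnc(S[C@@H]2O[C@H](COC(C)=O)[C@H](OC(C)=O)[C@H](OC(C)=O)[C@H]2OC(C)=O)s1` is still to be measured in this assay. For the measured compounds named here, it is obtained from compound 1 by hydrogen in place of dodec-3-en-1-yl on a saturated chain carbon, five bonds along the chain from a carbonyl carbon, the same change, at the same place, as the one taken from compound 2 to compound 3. The expectation for compound 4 rests on compound 1 at 54400 nM and on the step of a 5.2-fold higher number from compound 2 to compound 3 (0.71 log units; beyond the scatter) carried over to the acetylated core. The estimated step is a 4.0-fold higher number from compound 1 to compound 4 (0.61 log units; beyond the scatter). Compound 4 is therefore expected to give about 220000 nM, with a plausible range from 70000 nM to 700000 nM, and there is a real chance that this assay returns only a limit rather than a number, since compound 1 already sits at the high end of the measured values.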

Compound 4, half-maximal inhibitory concentration: 19800 nM
The estimate for compound 4 lay 11-fold (1.05 log units) above the measured number; measured number below the stated range.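

Replacing dodec-3-en-1-yl with hydrogen at this place does not carry from one core to the other in this assay: on the acetylated core the change gives a 2.7-fold lower number from compound 1 to compound 4 (0.44 log units; beyond the scatter), whereas on the free-hydroxyl core it gives a 5.2-fold higher number from compound 2 to compound 3 (0.71 log units; beyond the scatter). The two outcomes run in opposite directions, so a step read on one of these cores cannot serve as a guide to the other, and the gap between them is larger than repeat measurements would explain: the same change on two cores in this assay, a 5.2-fold higher number (0.71 log units; beyond the scatter) from compound 2 to compound 3 and a 2.7-fold lower number (0.44 log units; beyond the scatter) from compound 1 to compound 4, 14-fold (1.15 log units) apart, beyond the scatter of two such steps This rests on a single pair of compounds per core and a single chain change, so it shows that the effect of the change depends on the core for these four compounds, but it does not show what in the core is responsible or whether the reversal holds for any other chain.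

The compounds shown leave open how the numbers move along the chain, for example with a saturated octadecanoyl chain or a chain of intermediate length in place of the two at hand. They also leave open whether the reversal follows the acetyl groups as such, which a core carrying benzoyl esters or only some of the acetyl groups could test.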